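The source may hold more compounds than are shown below. What is called first, only, known or untested is meant among the compounds shown, and "the series" means these compounds.

Working notes on the series. Three analogues of the shared core of compound 1 `O=C(CN1C(=O)/C(=C/c2ccc(-c3ccc(Cl)cc3)o2)SC1=S)NCc1ccc(C(F)(F)F)cc1` have numbers in a functional assay on K562 cells (Homo sapiens) for cytotoxicity, read by MTT assay, with a stated time of 72 h; a lower number here means a stronger inhibitor, a higher number a weaker inhibitor. Compound 1 gives 155000 nM. Compound 2 `N#Cc1cc(NC(=O)CN2C(=O)/C(=C/c3ccc(-c4ccc(Cl)cc4)o3)SC2=S)ccc1C(F)(F)F` sits at the assay limit of > 250000 nM in this assay, at which 1 of the 3 values shown sits, and reports only > 250000 nM, a limit and not a number. Compound 3 `O=C(CN1C(=O)/C(=C/c2ccc(-c3ccc(Cl)cc3)o2)SC1=S)NCc1ccc(Br)cc1` gives 68000 nM, the lowest of the two numbers shown; the step of a 2.3-fold lower number from compound 1 to compound 3 (0.36 log units; beyond the scatter) is modest, and an at least 3.6-fold lower number from compound 2 to compound 3 (0.56 log units; beyond the scatter) is at least modest. Compound 4 `O=C(CN1C(=O)/C(=C/c2ccc(-c3ccc(Cl)cc3)o2)SC1=S)NCc1ccccc1Cl` differs from compound 3 by 2-chlorophenyl in place of 4-bromophenyl on a saturated chain carbon bound to an amide-type nitrogen. Both measured steps touch the same aryl group, and the halogen swap in a 2.3-fold lower number from compound 1 to compound 3 (0.36 log units; beyond the scatter) was small. A small step, likely toward a somewhat higher number, is expected for a 1.5-fold higher number from compound 3 to compound 4 (0.17 log units; within the scatter). Compound 4 is estimated at 100000 nM, within 40000 nM to 250000 nM.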

Compound 4, half-maximal inhibitory concentration: 64000 nM
Estimate against measurement, compound 4: 1.6-fold (0.19 log units) above, within the range that was stated.
By their numbers in this assay, from the lowest: compounds 4 and 3 (each within the scatter of the next); then compound 1. At a limit, above all of these: compound 2.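

At this position, 2-chlorophenyl and 4-bromophenyl cannot be told apart in this assay: a 1.1-fold lower number from compound 3 to compound 4 (0.03 log units; within the scatter). The step of a 2.4-fold lower number from compound 1 to compound 4 (0.38 log units; beyond the scatter) is modest, so both halogen-bearing benzyl groups now give lower numbers than 4-(trifluoromethyl)benzyl. The step of an at least 3.9-fold lower number from compound 2 to compound 4 (0.59 log units; beyond the scatter) is a floor and not a measured size: the limit of > 250000 nM in this assay, at which 1 of the 4 values shown sits.

The swap from 4-bromophenyl to 2-chlorophenyl changes both the halogen and its place on the ring, and 2-bromophenyl or 4-chlorophenyl would be needed to separate the two. As far as these compounds go, how an amine or a carboxylic acid on this ring would read remains open.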